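Swapping Selenium for Sulfur on the Shared Core

The compounds below may be only part of what the source reports. "The series", "measured", "known", "first", "only" and "open" are said of these compounds alone.

Measured so far:
compound 1 `CCCCC[Se]c1nc(NCc2ccccc2)c2ccccc2n1`: 34500 nM
compound 2 `[SeH]c1nc(NCc2ccccc2)c2ccccc2n1`: an assay limit, > 100000 nM
compound 3 `C[Se]c1nc(NCc2ccccc2)c2ccccc2n1`: 39800 nM

In a functional assay on CCRF-CEM cells (Homo sapiens) for cytotoxicity, read by MTT assay, with a stated time of 72 h (on this read-out higher numbers stand for weaker inhibition of growth and lower numbers for stronger inhibition of growth), compound 3 holds the highest of the two numbers shown, with compound 1 sitting within the scatter of it (a 1.2-fold higher number from compound 1 to compound 3 (0.06 log units; within the scatter)). Compound 4 `CSc1nc(NCc2ccccc2)c2ccccc2n1` differs from compound 3 by a group of 2 heavy atoms (1 carbon, 1 sulfur; no ring) in place of a group of 2 heavy atoms (1 carbon, 1 selenium; no ring), on an aromatic carbon. The measured steps concern only the chain on the selenium: a 1.2-fold higher number from compound 1 to compound 3 (0.06 log units; within the scatter) and an at least 2.5-fold lower number from compound 2 to compound 3 (0.40 log units; beyond the scatter). Neither exchanges selenium for sulfur, so they give no direct guide for this change. With a group of the same size entering, compound 4 is expected to stay close to compound 3, with no step beyond the scatter: a 1.1-fold higher number from compound 3 to compound 4 (0.05 log units; within the scatter). The estimate for compound 4 is 45000 nM, in a range from 15000 nM to 130000 nM.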

Compound 4, concentration for 50% growth inhibition: 87900 nM
Compound 4: the middle estimate sits 2.0-fold (0.29 log units) below what was measured; low and high end bracket the measured number.
By their numbers in this assay, from the lowest: compounds 1 and 3 (each within the scatter of the next); then compound 4. At a limit, above all of these: compound 2.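

In this assay the atom on this aromatic carbon counts, not only the chain on it: a 2.2-fold higher number from compound 3 to compound 4 (0.34 log units; beyond the scatter) means weaker inhibition of growth when sulfur replaces selenium and the methyl stays. Methylsulfanyl also falls behind the pentyl chain on selenium, with a 2.5-fold higher number from compound 1 to compound 4 (0.41 log units; beyond the scatter) for that whole exchange. Compound 2 stands at a limit: the limit of > 100000 nM in this assay, at which 1 of the 4 values shown sits. The remaining step is an at least 1.1-fold lower number from compound 2 to compound 4 (0.05 log units; that floor lies within the scatter), and its floor lies within the scatter, so no order can be read from it.

Still open, on these data alone, is whether sulfur brings the same loss when it carries a pentyl chain, and how an amine or a carboxylic acid would compare on this carbon.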